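This account rests on a few compounds, and the source may have more. Where it says the series, first, only, none or still open, it means among the compounds named here.

Compound 1 `CCCC(=O)N1CCC(NS(=O)(=O)c2ccc(NC(=O)c3ccc(C)cc3)c3ccccc23)CC1`: 9.5 nM
Compound 2 `CCCC(=O)N1CCC(NS(=O)(=O)c2ccc(NC(=O)c3ccoc3)c3ccccc23)CC1`: 1520 nM

Among the measured compounds shown here, in an in vitro functional assay on CHO/Galpha16 cells for antagonist activity at C-C chemokine receptor type 8 (Homo sapiens), read by FLIPR (on this read-out higher numbers stand for weaker inhibition and lower numbers for stronger inhibition), compound 2 gives the highest of the two numbers; its nearest neighbour is compound 1, and the one measured step, a 160-fold higher number from compound 1 to compound 2 (2.20 log units; beyond the scatter), was large. Compound 3 `CCCC(=O)N1CCC(NS(=O)(=O)c2ccc(NC(=O)C3CCCC3)c3ccccc23)CC1` carries the change (cyclopentyl in place of furan-3-yl on a carbonyl carbon). For the measured compounds named here, no measured step bears directly on a non-aromatic ring here; the step from compound 1 to compound 2 shows only that the group on this carbonyl carbon matters greatly in this assay. For compound 3 a moderate drop in the number is expected, a 5.1-fold lower number from compound 2 to compound 3 (0.70 log units; beyond the scatter), giving an estimate of 300 nM with a range of 40 nM to 2500 nM.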

Compound 3, half-maximal inhibitory concentration: 365 nM
The estimate for compound 3 lay 1.2-fold (0.09 log units) below the measured number; the measured number falls inside the stated range.
By their numbers in this assay, from the lowest: compound 1; then compound 3; then compound 2.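

In this assay, cyclopentyl in place of furan-3-yl on this carbonyl carbon gives a 4.2-fold lower number from compound 2 to compound 3 (0.62 log units; beyond the scatter) and so recovers only a modest part of what compound 2 lost. Set against the 4-methylphenyl, the same ring gives a 38-fold higher number from compound 1 to compound 3 (1.58 log units; beyond the scatter) as a large loss, so neither five-membered ring on this carbonyl carbon comes close to compound 1. Nothing available accounts for these differences.

From the compounds shown here alone, it remains open whether cyclohexyl or a longer chain such as pentyl would come nearer to compound 1. Going by these compounds, it is also open whether a plain phenyl, without the methyl, would hold the low number of compound 1.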